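The compounds below may be only part of what the source reports. "The series", "measured", "known", "first", "only" and "open" are said of these compounds alone.

Compound 1 `Cc1ccc(NC2=CC(=O)c3nc4n(c3C2=O)[C@H]2OC[C@@H](O)[C@H]2OC4)cc1` — 3480 nM
Compound 2 `O=C1C=C(NCc2ccccc2)C(=O)c2c1nc1n2[C@H]2OC[C@@H](O)[C@H]2OC1` — a limit, > 8000 nM
Compound 3 `O=C1C=C(Nc2ccccc2)C(=O)c2c1nc1n2[C@H]2OC[C@@H](O)[C@H]2OC1` — 4970 nM

In a functional assay on ECa-109 cells for inhibition, with ECa-109 cell line (Homo sapiens) as the target, read by sulforhodamine B assay (on this read-out higher numbers stand for weaker inhibition and lower numbers for stronger inhibition), compound 3 gives 4970 nM, the higher of the two numbers; compound 1 gives 3480 nM, and the gap, a 1.4-fold higher number from compound 1 to compound 3 (0.15 log units; within the scatter), separates nothing. For compound 2 only a limit was recorded, (the limit of > 8000 nM in this assay, at which 1 of the 3 values shown sits). Moving from an aromatic to a non-aromatic group on the amine nitrogen gave an at least 2.2-fold higher number from compound 1 to compound 2 (0.36 log units; beyond the scatter), and the reverse move gave an at least 1.6-fold lower number from compound 2 to compound 3 (0.20 log units; that floor lies within the scatter).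

Compound 4 `O=C1C=C(NC2CCCCC2)C(=O)c2c1nc1n2[C@H]2OC[C@@H](O)[C@H]2OC1` differs from compound 3 in one place: cyclohexyl in place of phenyl on an amine nitrogen. Again an aromatic group on that nitrogen gives way to a non-aromatic one, so the steps involving compound 2 are the ones that bear on it, and both point to a weaker number, though neither is large. A modest rise in this assay is therefore expected, possibly ending at the same limit. Compound 4 is expected to give about 8500 nM, within 3500 nM to 20000 nM. The expected step is a 1.7-fold higher number from compound 3 to compound 4 (0.23 log units; within the scatter).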

Compound 4, half-maximal inhibitory concentration: > 16000 nM
Compound 4 ended at the assay's limit (the forecaster's own chance of this, stated with the estimate: 50%); at least 1.8-fold (0.27 log units) between middle value and limit.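

In this assay, exchanging the aromatic ring on the amine nitrogen for a non-aromatic one weakens inhibition, with an at least 3.2-fold higher number from compound 3 to compound 4 (0.50 log units; beyond the scatter) and an at least 4.5-fold higher number from compound 1 to compound 4 (0.66 log units; beyond the scatter). Phenyl and cyclohexyl are both six-membered carbon rings with the same count of carbon atoms, so this change isolates the loss of the aromatic ring more cleanly than the benzyl group of compound 2 could. The true size of the loss remains unknown, as compound 4 reached a limit rather than a number: the limit of > 16000 nM in this assay, at which 1 of the 4 values shown sits.

Compound 2 and compound 4 both end at limits, so the step between them cannot be read. As far as these compounds go, it also remains open how a straight butyl chain, or a phenyl ring carrying a methoxy group or an amine, would behave on this nitrogen.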